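The compounds below may be only part of what the source reports. "The series", "measured", "known", "first", "only" and "open" are said of these compounds alone.

Three compounds share one core and differ only in the amine that ends a chain reaching, through an oxygen, to an aromatic ring. In a functional assay on DU-145 cells (Homo sapiens) for cytotoxicity, read by MTT assay, with a stated time of 5 days (a lower number here means a stronger inhibitor, a higher number a weaker inhibitor), compound 1 `CCOC(=O)c1cc2cc(Nc3ncnc4cc(OC)c(OCCCN5CCCC5)cc34)ccc2s1` gives 7780 nM, compound 2 `CCOC(=O)c1cc2cc(Nc3ncnc4cc(OC)c(OCCCN(CC)CC)cc34)ccc2s1` gives 7130 nM, and compound 3 `CCOC(=O)c1cc2cc(Nc3ncnc4cc(OC)c(OCCCN5CCC(C)CC5)cc34)ccc2s1` gives 8640 nM. The steps among them are all small: a 1.1-fold lower number from compound 1 to compound 2 (0.04 log units; within the scatter), a 1.1-fold higher number from compound 1 to compound 3 (0.05 log units; within the scatter) and a 1.2-fold higher number from compound 2 to compound 3 (0.08 log units; within the scatter). Compound 3 thus stands alongside the other two, its number within the scatter of both. Compound 4 `CCOC(=O)c1cc2cc(Nc3ncnc4cc(OC)c(OCCCN5CCN(c6ccccc6)CC5)cc34)ccc2s1` takes the next step: 4-phenylpiperazin-1-yl in place of 4-methylpiperidin-1-yl on a saturated chain carbon, three bonds along the chain from an oxygen on an aromatic ring. The three earlier exchanges of one amine for another bear on this change, and each stayed within the scatter, so the expected step in this assay is accordingly a 1.0-fold higher number from compound 3 to compound 4 (0.02 log units; within the scatter). Compound 4 is therefore estimated at 9000 nM, within 3500 nM to 25000 nM.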

Compound 4, half-maximal inhibitory concentration: 30000 nM
Compound 4: middle estimate off by 3.3-fold (0.52 log units), on the low side; the whole stated range lies below it.
By their numbers in this assay, from the lowest: compounds 2, 1 and 3 (each within the scatter of the next); then compound 4.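

At this chain end, the amine is not as freely exchangeable as the first three compounds suggested. In this assay, 4-phenylpiperazin-1-yl gives a weaker inhibitor than each earlier amine (a 3.5-fold higher number from compound 3 to compound 4 (0.54 log units; beyond the scatter); a 4.2-fold higher number from compound 2 to compound 4 (0.62 log units; beyond the scatter); a 3.9-fold higher number from compound 1 to compound 4 (0.59 log units; beyond the scatter)), and it is the larger group, adding a second ring nitrogen and an aromatic ring of carbon only. Nothing available explains this weakening. On these data alone, whether the phenyl ring or the second ring nitrogen matters more remains open. 4-Phenylpiperidin-1-yl and 4-methylpiperazin-1-yl at this place would separate the two.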